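Swapping the Benzyl Substituent on a Shared Core

The source may report more compounds than this note shows. Statements on the series, on what has been measured and on what is new or still open speak of the compounds shown alone.

Measured compounds:
- compound 1 `COc1ccc2c(=O)c(-c3cc(OC)c(OC)cc3OC)coc2c1`: 2040 nM
- compound 2 `COc1cc(OC)c(-c2coc3cc(OCc4ccccc4F)ccc3c2=O)cc1OC`: 1280 nM
- compound 3 `COc1cc(OC)c(-c2coc3cc(OCc4ccccc4C)ccc3c2=O)cc1OC`: 1860 nM

The three measured compounds share one core and differ only at a saturated chain carbon bound to an oxygen on an aromatic ring. In a functional assay on HepG2 cells (Homo sapiens) for antiproliferative activity, read by MTT assay, with a stated time of 24 h (a higher number here means a weaker inhibitor, a lower number a stronger inhibitor), compound 3 gives 1860 nM, the second highest of the three numbers; its nearest neighbour is compound 1 and its furthest is compound 2, and both gaps sit within the scatter of the assay.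

The step to compound 4 `COc1cc(OC)c(-c2coc3cc(OCc4cccc(F)c4)ccc3c2=O)cc1OC` is 3-fluorophenyl in place of 2-methylphenyl on a saturated chain carbon bound to an oxygen on an aromatic ring. For the measured compounds named here, two measured steps bear on it. From compound 1, where only hydrogen stands at that carbon, adding a 2-fluorophenyl gave a 1.6-fold lower number from compound 1 to compound 2 (0.20 log units; within the scatter), and adding a 2-methylphenyl gave a 1.1-fold lower number from compound 1 to compound 3 (0.04 log units; within the scatter); the direct comparison of the two gives a 1.5-fold higher number from compound 2 to compound 3 (0.16 log units; within the scatter). None of these changes moved the number beyond the scatter, so a fluorine placed at a different point on the same ring is expected to do little as well. The estimate for compound 4 is therefore 1500 nM, with a range of 700 nM to 3200 nM, which is expected to mean a 1.2-fold lower number from compound 3 to compound 4 (0.09 log units; within the scatter).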

Compound 4, half-maximal inhibitory concentration: 1230 nM
Compound 4: middle estimate off by 1.2-fold (0.09 log units), on the high side; measured number inside the range.
By their numbers in this assay, from the lowest: compounds 4, 2, 3 and 1 (each within the scatter of the next).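

In this assay, for the compounds shown here, the new compound gives the first comparison in which only the place of the fluorine on the benzyl ring changes, and with 3-fluorophenyl in place of 2-fluorophenyl the result is a 1.0-fold lower number from compound 2 to compound 4 (0.02 log units; within the scatter), so that move leaves the reading within the scatter. Going by these compounds alone, the exchange of 2-methylphenyl for 3-fluorophenyl gives a 1.5-fold lower number from compound 3 to compound 4 (0.18 log units; within the scatter), and setting 3-fluorophenyl against the hydrogen of the core gives a 1.7-fold lower number from compound 1 to compound 4 (0.22 log units; within the scatter), which is the largest step so far and still does not leave the scatter; across the four compounds, neither the kind of substituent on the ring, nor the place of the fluorine, nor the presence of the ring itself has yet separated one number from another at this carbon. Nothing measured here offers a reason for this flat response.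

The compounds shown carry only hydrogen or a phenyl ring with a single fluoro or methyl substituent at this carbon, so it remains open whether an amine, a carboxylic acid or a longer chain there would move the number beyond the scatter. As far as these compounds go, it also remains open whether a phenyl ring bearing a trifluoromethyl or a nitrile would do so.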